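The source may report more compounds than this note shows. Statements on the series, on what has been measured and on what is new or still open speak of the compounds shown alone.

Measured compounds:

Compound 1 `OC[C@H]1O[C@@H](n2cnc3c(NCc4ccccc4Br)ncnc32)[C@H](O)[C@@H]1O` — in a functional assay on B16 cells (Mus musculus) for antiproliferative activity, with a stated time of 72 h (a lower number here means a stronger inhibitor, a higher number a weaker inhibitor), compound 1 gives > 166000 nM, which is a limit of the assay and not a number.

Compound 2 `OC[C@H]1O[C@@H](n2cnc3c(NCc4cccc(Br)c4)ncnc32)[C@H](O)[C@@H]1O` — in this assay compound 2 gives > 166000 nM, again a limit of the assay.

Compound 3 `OC[C@H]1O[C@@H](n2cnc3c(NCc4ccc(F)c(F)c4F)ncnc32)[C@H](O)[C@@H]1O` — in this assay compound 3 gives > 166000 nM, also a limit of the assay.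

Compound 2 therefore stands nowhere on a scale: its result is a limit, and the other two values shown are limits as well, all sitting at the limit of > 166000 nM in this assay, at which 3 of the 3 values shown sit. The three single-point changes among the measured compounds are a step that the two limits leave unreadable from compound 1 to compound 2, a step that the two limits leave unreadable from compound 1 to compound 3 and a step that the two limits leave unreadable from compound 2 to compound 3; each is unreadable, since both ends sit at the limit, so none of them gives a size or a direction.

Compound 4 `COc1cccc(CNc2ncnc3c2ncn3[C@@H]2O[C@H](CO)[C@@H](O)[C@H]2O)c1O` differs from compound 2 by 2-hydroxy-3-methoxyphenyl in place of 3-bromophenyl on a saturated chain carbon bound to a nitrogen on an aromatic ring. Among the compounds with values here, no measured step bears on this change with a readable size, so the expectation can rest only on the fact that every compound measured so far in this assay returned a limit. The step that the limit leaves unreadable from compound 2 to compound 4 is expected to be unresolved rather than a measured shift. For compound 4 the estimated value in this assay is 200000 nM, with a range from 50000 nM to 1000000 nM, and a limit is the most likely outcome.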

Compound 4, half-maximal inhibitory concentration: > 166000 nM
Compound 4: only a limit was reported (the forecaster's own chance of this, stated with the estimate: 80%); the middle value lies beyond the limit too.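

In this assay compound 4 gives > 166000 nM, which is a limit of the assay and not a number. No new step can be read, since the changes linking compound 4 to compounds 1, 2 and 3 join limits and give neither size nor direction. Left open is whether any phenyl group at this place gives a readable value in this assay, as all the results shown coincide: the limit of > 166000 nM in this assay, at which 4 of the 4 values shown sit.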